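A Longer Acyl Chain on the Amide of Compound 1

This account rests on a few compounds, and the source may have more. Where it says the series, first, only, none or still open, it means among the compounds named here.

The measured compounds and their values in a functional assay on MGC-803 cells (Homo sapiens) for inhibition, read by MTT assay, with a stated time of 48 h; on this read-out lower numbers stand for stronger inhibition and higher numbers for weaker inhibition:
- compound 1, `COc1ccc(CN(C(C)=O)c2cc(OC)c(OC)c(OC)c2)cc1O`, gives 79 nM
- compound 2, `COc1ccc(CNc2cc(OC)c(OC)c(OC)c2)cc1`, gives 11400 nM
- compound 3, `COc1ccc(CNc2cc(OC)c(OC)c(OC)c2)cc1[N+](=O)[O-]`, gives 19400 nM

Compound 1 stands at the lowest number of the three, and its distance from compound 2 and from compound 3 is beyond the scatter in both cases. Among the compounds with values here, compound 2 and compound 3 share an unsubstituted amine in place of the acetylated nitrogen of compound 1, and the one step measured between them, a 1.7-fold higher number from compound 2 to compound 3 (0.23 log units; within the scatter), falls within the scatter.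

Compound 4, `C/C=C/C(=O)N(Cc1ccc(OC)c(O)c1)c1cc(OC)c(OC)c(OC)c1`, differs from compound 1 in one place: prop-1-en-1-yl in place of methyl on a carbonyl carbon. Neither measured step touches this carbonyl carbon, so nothing in the data speaks directly to the size or direction of the change. Within the data shown here, the only measured step concerns a ring substituent and tells nothing about the acyl group. In the absence of a bearing step, the expectation for this assay is a step of a 1.1-fold higher number from compound 1 to compound 4 (0.06 log units; within the scatter), that is, no change beyond the scatter. Compound 4 is therefore estimated at 90 nM, with a range from 30 nM to 300 nM.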

Compound 4, half-maximal inhibitory concentration: 27 nM
Compound 4: middle estimate off by 3.3-fold (0.52 log units), on the high side; the whole stated range lies above it.
By their numbers in this assay, from the lowest: compound 4; then compound 1; then compounds 2 and 3 (each within the scatter of the next).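

In this assay, changing the acyl group gives a 2.9-fold lower number from compound 1 to compound 4 (0.47 log units; beyond the scatter) and so shows that this carbonyl carbon is a place where a change moves the number beyond the usual scatter, though only modestly. Within the data shown here, the one step available earlier concerned a ring substituent and stayed within the scatter, so it gave no sign of how the series would respond to a change on the amide side, whereas here methyl can give way to the larger prop-1-en-1-yl group, with its double bond outside aromatic rings, and the number goes down rather than up. No measurement at hand offers any explanation for this result.

The longer chain and the double bond enter together in this single step, and a saturated propyl group on the same carbonyl carbon would pull the two apart. Going by these compounds, whether a still longer chain or a phenyl group at this place would lower the number further or raise it again remains open.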